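The compounds below may be only part of what the source reports. "The series", "measured", "known", "first", "only" and "open" are said of these compounds alone.

Within the data shown here, compound 2 `Cc1nc2ccccc2n1-c1csc(Nc2ccc(Br)cc2)n1` is the one compound of three with a number rather than a limit in a functional assay on RKO cells (Homo sapiens) for cytotoxicity, read by resazurin assay, with a stated time of 72 h; on this read-out lower numbers stand for stronger inhibition and higher numbers for weaker inhibition: compound 2 gives 60000 nM. Compound 1 `COc1ccc(Nc2nc(-n3ccnc3C)cs2)cc1` reaches only a limit, and in this assay compound 1 gives > 100000 nM. Compound 3 `Cc1nccn1-c1csc(Nc2ccc(Br)cc2)n1` likewise reaches only a limit, and in this assay compound 3 gives > 100000 nM. The change from compound 3 to compound 1 methoxy in place of bromo on an aromatic carbon gives a step that the two limits leave unreadable from compound 3 to compound 1 because the limit of > 100000 nM in this assay, at which 2 of the 3 values shown sit, caps both ends. How the core of compound 2 differs from that of compound 3 is not broken down here. Compound 4 `COc1ccc(Nc2nc(-n3c(C)nc4ccccc43)cs2)cc1`, not yet measured, carries the same change methoxy in place of bromo on an aromatic carbon on the core of compound 2. For compound 4 the expected step of a 1.7-fold higher number from compound 2 to compound 4 (0.22 log units; within the scatter) rests on compound 2 giving 60000 nM and on that unreadable earlier step. Compound 4 is estimated at 100000 nM, between 40000 nM and 300000 nM.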

Compound 4, half-maximal inhibitory concentration: 52500 nM
Compound 4: middle estimate off by 1.9-fold (0.28 log units), on the high side; low and high end bracket the measured number.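

In this assay, methoxy in place of bromo on the core of compound 2 gives a 1.1-fold lower number from compound 2 to compound 4 (0.06 log units; within the scatter), so on this core the two compounds cannot be told apart. The same change on the core of compound 3 cannot be read, so the data do not show whether the result carries from one core to the other, because compound 3 and compound 1 both stop at a limit: the limit of > 100000 nM in this assay, at which 2 of the 4 values shown sit. What remains is one readable step on one core, not a rule for the series.

The compounds shown leave open how an amine or a carboxylic acid in place of bromo or methoxy would read. They also leave open whether a longer chain than methoxy would move the number beyond the usual scatter.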